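Working notes: from compound 3 to compound 4

This account rests on a few compounds, and the source may have more. Where it says the series, first, only, none or still open, it means among the compounds named here.

compound 1 `CC[C@H]1CC[C@H](c2ccc(NC(=S)Nc3cccc(C(F)(F)F)c3)cc2)CC1`: 9000 nM
compound 2 `N#Cc1ccc(NC(=S)Nc2cccc(C(F)(F)F)c2)cc1`: 10000 nM
compound 3 `COc1cccc(NC(=S)Nc2cccc(C(F)(F)F)c2)c1`: 52000 nM

In an ADME assay on MDBK cells (Bos taurus) for cytotoxicity, read by MTT assay, with a stated time of 96 h (a higher number here means that more compound is tolerated, a lower number that less compound is tolerated), compound 3 stands highest of the three at 52000 nM, clearly above compound 2 at 10000 nM and compound 1 at 9000 nM. Compound 4 `FC(F)(F)c1cccc(NC(=S)Nc2ccccc2)c1` has no value yet in this assay. Its structure departs from that of compound 3 by one change: hydrogen in place of methoxy on an aromatic carbon.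

Among the measured compounds shown here, the only measured step is a 1.1-fold higher number from compound 1 to compound 2 (0.05 log units; within the scatter), with cyano in place of 4-ethylcyclohexyl on an aromatic carbon. It lies within the scatter, but it involves neither methoxy nor hydrogen, so it bears only loosely on this change. For the measured compounds named here, no measured step removes a methoxy. The one indirect hint is that compound 1 at 9000 nM and compound 2 at 10000 nM both lack the methoxy and both give lower numbers than compound 3. Losing the methoxy is therefore expected to move the number part of the way towards theirs, with wide uncertainty. The expected change, a modest one to a lower number, is a 2.1-fold lower number from compound 3 to compound 4 (0.32 log units; beyond the scatter). For compound 4 the estimate is 25000 nM, with an expected range from 9000 nM to 70000 nM.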

Compound 4, half-maximal cytotoxic concentration: 49000 nM
Estimate against measurement, compound 4: 2.0-fold (0.29 log units) below, and the stated range covers the measured number.
By their numbers in this assay, from the lowest: compounds 1 and 2 (each within the scatter of the next); then compounds 4 and 3 (each within the scatter of the next).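

In this assay, hydrogen in place of methoxy on an aromatic carbon, meta to a large group, gives a 1.1-fold lower number from compound 3 to compound 4 (0.03 log units; within the scatter) and so shows that at this position the methoxy can be removed without a shift that stands clear of the scatter. Compound 4 also gives the series a reference with no substituent at the place of change: hydrogen in place of cyano gives a 4.9-fold higher number from compound 2 to compound 4 (0.69 log units; beyond the scatter) and hydrogen in place of 4-ethylcyclohexyl gives a 5.4-fold higher number from compound 1 to compound 4 (0.74 log units; beyond the scatter), so both substituted compounds now stand apart from that reference in the same direction. Among the compounds shown here, the earlier compounds could not show this, as their one step compared two substituents with each other and left the effect of either against hydrogen unread.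

As far as these compounds go, whether an amine, a carboxylic acid or a longer alkoxy chain on this aromatic carbon would also stay within the scatter of compound 4 remains open, as does whether the methoxy result carries over to other places on the ring. No measurement at hand gives a reason for any of these steps.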